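A few compounds are considered here, and "the series" means these few. Any claim that something is new, unique, unknown or untested is made for them only; others in the source may bear on it.

Measured in a functional assay on LNCaP cells (Homo sapiens) for inhibition, read by MTT assay; a lower number here means a stronger inhibitor of growth, a higher number a weaker inhibitor of growth:
- compound 1 `CC1=C(/C=C/C(C)=C/C=C/C(C)=C\C(=O)Nc2ccccc2)C(C)(C)CCC1n1ccnc1`: 2690 nM
- compound 2 `CC1=C(/C=C/C(C)=C/C=C/C(C)=C\C(=O)Nc2cccc(F)c2)C(C)(C)CCC1n1ccnc1`: 2690 nM
- compound 3 `CC1=C(/C=C/C(C)=C/C=C/C(C)=C\C(=O)NCc2ccc(O)cc2)C(C)(C)CCC1n1ccnc1`: 1690 nM

All three values lie within the scatter of one another, so compound 3, at 1690 nM, cannot be ranked against the other two.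

Compound 4 `CC1=C(/C=C/C(C)=C/C=C/C(C)=C\C(=O)NCc2ccccc2)C(C)(C)CCC1n1ccnc1` has hydrogen in place of hydroxy on an aromatic carbon, para to a large group, turning 4-hydroxybenzyl into benzyl: hydrogen in place of hydroxy on an aromatic carbon.

Among the measured compounds shown here, no measured step isolates this change. The nearest evidence is indirect. Replacing the aryl group on the amide nitrogen gave a 1.6-fold lower number from compound 1 to compound 3 (0.20 log units; within the scatter) and a 1.6-fold lower number from compound 2 to compound 3 (0.20 log units; within the scatter), and a single substitution on the aromatic ring gave no change at the digits printed from compound 1 to compound 2 (within the scatter). None of these steps exceeds the scatter, so no real shift is expected in this assay, and no direction can be argued with confidence.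

The expected step is a 1.2-fold higher number from compound 3 to compound 4 (0.07 log units; within the scatter), which would remain within the scatter. For compound 4 the estimated value is 2000 nM, with an expected range of 1000 nM to 4000 nM.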

Compound 4, concentration for 50% growth inhibition: > 100000 nM
Compound 4 was reported as a limit (the forecaster's own chance of this, stated with the estimate: 3%); middle value at least 50-fold (1.69 log units) away from the limit.
By their numbers in this assay, from the lowest: compounds 3, 1 and 2 (each within the scatter of the next). At a limit, above all of these: compound 4.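

In this assay, compound 4 stands as a limit of the assay and not as a number: the limit of > 100000 nM in this assay, at which 1 of the 4 values shown sits.

Among the compounds shown here, the para position of the benzyl group is the first place where a change moves the read-out beyond the scatter, with hydrogen in place of hydroxy giving an at least 59-fold higher number from compound 3 to compound 4 (1.77 log units; beyond the scatter). The unsubstituted benzyl also separates from the phenyl and 3-fluorophenyl amides, with an at least 37-fold higher number from compound 1 to compound 4 (1.57 log units; beyond the scatter) and an at least 37-fold higher number from compound 2 to compound 4 (1.57 log units; beyond the scatter), so the absence of a hydroxy is tolerated on phenyl in compound 1 but not on benzyl in compound 4.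

Going by these compounds, it remains open whether the requirement is specific to hydroxy or would also be met by methoxy, an amine or fluorine at this position of the benzyl group. On these data alone, the effect of hydroxy on the phenyl amide, as a 4-hydroxyphenyl group, also remains open.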